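The source may report more compounds than this note shows. Statements on the series, on what has been measured and on what is new or still open speak of the compounds shown alone.

Compound 2 `Nc1nc(Cc2ccccc2Cl)nc2cn(-c3ccccc3)nc12` gives 22% in an assay on CHO cells for displacement of a labelled ligand from adenosine receptor A3 (Homo sapiens), read by scintillation counting, tested at 1 uM (a lower number here means less inhibition, a higher number more inhibition at the concentration tested (going by the name of the read-out)), the lowest of the two numbers in hand; compound 1 `Cc1ccc(Cc2nc(N)c3nn(-c4ccccc4)cc3n2)cc1` gives 39%. Among the compounds with values here, the one measured step, a number 17 percentage points lower from compound 1 to compound 2 (beyond the scatter), changes both the substituent and its position on the phenyl, so it bears only loosely on the present move. Compound 3 `Nc1nc(Cc2cccc(Cl)c2)nc2cn(-c3ccccc3)nc12` differs from compound 2 by 3-chlorophenyl in place of 2-chlorophenyl on a saturated chain carbon bound to an aromatic carbon. Within the data shown here, with no step of this exact kind measured, the direction is open; a small rise toward the level of compound 1 is a reasonable guess. For compound 3 the expected step is a number 8 percentage points higher from compound 2 to compound 3 (within the scatter), giving an estimate of 30% with a range from 12% to 50%.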

Compound 3, a percentage reported as inhibition, at one concentration (the size of the read-out at that concentration, not a potency): 42%
For compound 3 the middle estimate is 12 percentage points below the measured one, and the stated range covers the measured number.
By their numbers in this assay, from the lowest: compound 2; then compounds 1 and 3 (each within the scatter of the next).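

Shifting the chlorine alone is enough to matter in this assay, with a number 20 percentage points higher from compound 2 to compound 3 (beyond the scatter) at this place on the saturated chain carbon. The 3-chlorophenyl and 4-methylphenyl groups cannot be told apart here, with a number 3 percentage points higher from compound 1 to compound 3 (within the scatter) as the comparison. No evidence explains the gap between the two chlorophenyl groups.

Still open, going by these compounds, is whether a methoxy group or an amine in place of the chlorine in 3-chlorophenyl would keep this level of inhibition. On these data alone, a longer chain carrying the 3-chlorophenyl group also remains untested in these compounds.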